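Compound 4: An Exchange Without a Starting Number

The source may hold more compounds than are shown below. What is called first, only, known or untested is meant among the compounds shown, and "the series" means these compounds.

In an ADME assay on MT4 cells (Homo sapiens) for cytotoxicity, read by MTT assay, with a stated time of 96 h (on this read-out higher numbers stand for lower toxicity in this test and lower numbers for higher toxicity in this test), compound 3 (`C/C(=N\NC(N)=O)c1ccc2[nH]c(C3CCCCC3)nc2c1`) stands at "not determined" (no result reported) and so offers no number to start from. Compound 4 (`C/C(=N\NC(N)=S)c1ccc2[nH]c(C3CCCCC3)nc2c1`) differs from compound 3 by a single exchange (a group of 3 heavy atoms (1 carbon, 1 nitrogen, 1 sulfur; no ring) in place of a group of 3 heavy atoms (1 carbon, 1 nitrogen, 1 oxygen; no ring), on an amine nitrogen) in which carbamoyl leaves. Among the measured compounds shown here, only two related compounds have readings. In this assay compound 1 (`C/C(=N\NC(N)=S)c1ccc2[nH]c(-c3ccccc3)nc2c1`) reads >= 100000 nM and that is a limit, not a number. Compound 2 (`COc1ccc(-c2nc3cc(/C(C)=N/NC(N)=S)ccc3[nH]2)cc1`) reads 5000 nM on the same scale. For the measured compounds named here, the only measured step is an at least 20-fold lower number from compound 1 to compound 2 (1.30 log units; beyond the scatter) and it is large, but it comes from methoxy in place of hydrogen on an aromatic carbon, not from the exchange at issue. It therefore sets no size for this exchange, and with no number for compound 3, no size or direction of step can be expected. The estimate instead rests on the reading of compound 2 at 5000 nM. It also allows for a result toward the limit seen for compound 1. Compound 4 is expected near 25000 nM in this assay with an estimated range from 5000 nM to 100000 nM for its reading.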

Compound 4, half-maximal cytotoxic concentration: 48000 nM
Compound 4: middle estimate off by 1.9-fold (0.28 log units), on the low side, and the stated range covers the measured number.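

Among the compounds shown here, until now, the only change at this aromatic carbon was a methoxy group added to the phenyl ring; compound 4 shows that replacing the ring group itself also shifts the reading in this assay. Cyclohexyl in place of 4-methoxyphenyl gives a 9.6-fold higher number from compound 2 to compound 4 (0.98 log units; beyond the scatter), while cyclohexyl in place of phenyl gives an at least 2.0-fold lower number from compound 1 to compound 4 (0.31 log units; beyond the scatter), so the cyclohexyl compound reads on opposite sides in the two comparisons. Compound 1 stands at a limit and not at a number, so the second step gives only a bound: the limit of >= 100000 nM in this assay, at which 1 of the 4 values shown sits.

On these data alone, the step from compound 3 to compound 4 cannot be read, so the effect of the exchange at the amine nitrogen on its own remains open. As far as these compounds go, it also remains open how an amine or a longer chain would read on this aromatic carbon in place of cyclohexyl.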